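Swapping a Fluoro for a Chloro on the Pyridine Ring

The source may report more compounds than this note shows. Statements on the series, on what has been measured and on what is new or still open speak of the compounds shown alone.

Compound 1 `COc1cccc(S(=O)(=O)/C=C/c2ccccn2)c1` gives 98.9% in an ADME assay on BV-2 cells (Mus musculus) for cytotoxicity, with a stated time of 24 h, tested at 50 uM; on this read-out lower numbers stand for a stronger effect and higher numbers for a weaker effect at the one concentration tested. Compound 2 `COc1cccc(S(=O)(=O)/C=C/c2ncccc2F)c1` gives 97.4% there, a number that sits within the scatter of compound 1, with the step of a number 1.5 percentage points lower from compound 1 to compound 2 (within the scatter) being the only measured one. Compound 3 `COc1cccc(S(=O)(=O)/C=C/c2ncccc2Cl)c1` carries chloro in place of fluoro on an aromatic carbon. Going by the values given here, the one step known, a halogen entering in place of hydrogen, stayed within the scatter, so compound 3 is expected to show a number 1.4 percentage points lower from compound 2 to compound 3 (within the scatter), no change beyond the scatter. Compound 3 is therefore estimated at 96%, between 87% and 100%.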

Compound 3, a percentage reported as activity, at one concentration (the size of the read-out at that concentration, not a potency): 82.2%
For compound 3 the middle estimate is 13.8 percentage points above the measured one, and the stated range ends above it.
By their numbers in this assay, from the lowest: compound 3; then compounds 2 and 1 (each within the scatter of the next).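

In this assay chloro on this aromatic carbon, ortho to a large group and two atoms from the ring nitrogen, gives a number 15.2 percentage points lower from compound 2 to compound 3 (beyond the scatter) when it replaces fluoro and a number 16.7 percentage points lower from compound 1 to compound 3 (beyond the scatter) when it replaces hydrogen. Fluoro in place of hydrogen had stayed within the scatter, so at this position the two halogens are not interchangeable. Nothing available accounts for the difference. Open, as far as these compounds go, is how bromo, methyl or an amine would read at this same position, and whether chloro would give a similar step elsewhere on the ring.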